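Amide nitrogen substituent swap on a shared hydroxypyridone core

The source may report more compounds than this note shows. Statements on the series, on what has been measured and on what is new or still open speak of the compounds shown alone.

Compound 1 `O=C(NCc1cccnc1)c1c(O)c2cccnc2n(-c2ccccc2)c1=O` and compound 2 `Cc1cnccc1NC(=O)c1c(O)c2cccnc2n(-c2ccccc2)c1=O` share one core and differ only at the amide-type nitrogen. In a functional assay on the whole organism for inhibition, with Rattus norvegicus as the target, read by paw edema, at a dose of 100 mg/kg by the oral route (on this read-out lower numbers stand for less inhibition and higher numbers for more inhibition at the one dose given (going by the name of the read-out)), compound 1 gives 25.5%, and in the same test compound 2 gives 26.9%. Among the measured compounds shown here, the one step measured so far, a number 1.4 percentage points higher from compound 1 to compound 2 (within the scatter), is within the scatter, so compound 2 and compound 1 cannot be told apart on these numbers.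

Compound 3 `COc1ccc(NC(=O)c2c(O)c3cccnc3n(-c3ccccc3)c2=O)cn1` carries the next change at the same nitrogen: 6-methoxypyridin-3-yl in place of 3-methylpyridin-4-yl on an amide-type nitrogen. For the measured compounds named here, the only step that bears on this place, a number 1.4 percentage points higher from compound 1 to compound 2 (within the scatter), was flat, and it replaced a larger part of the substituent than the present change does. No step beyond the scatter is therefore expected in this assay, in either direction. The change is estimated as a step of a number 0.9 percentage points lower from compound 2 to compound 3 (within the scatter). Compound 3 is expected to give 26%, with a range from 14% to 38%.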

Compound 3, a percentage reported as inhibition, in the whole organism at one dose (the size of the read-out at that dose, not a potency): 13.1%
Estimate against measurement, compound 3: 12.9 percentage points above; measured number below the stated range.
By their numbers in this assay, from the lowest: compound 3; then compounds 1 and 2 (each within the scatter of the next).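

In this assay the amide-type nitrogen proves not to be flat: the change to 6-methoxypyridin-3-yl gives a number 13.8 percentage points lower from compound 2 to compound 3 (beyond the scatter) and, against the (pyridin-3-yl)methyl group, a number 12.4 percentage points lower from compound 1 to compound 3 (beyond the scatter) with both steps set apart from the earlier step between the first two compounds. The read-out at this one dose therefore responds to the group on this nitrogen, with compound 3 lying apart from compounds 1 and 2. No data on hand bear on why the number falls.

On these data alone, the step from compound 2 to compound 3 swaps the whole group, so whether the methoxy or the ring attachment carries it stays open; pyridin-3-yl without methoxy, or 6-methylpyridin-3-yl, would bear on this. As far as these compounds go, whether a dimethylamino or a carboxylic acid in place of the methoxy gives a similar number also stays open.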